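Notes on the amidine-to-propylamino step at the ring carbon

This account rests on a few compounds, and the source may have more. Where it says the series, first, only, none or still open, it means among the compounds named here.

Compound 1 `Cc1nc2c(OCc3ccccc3)cccn2c1N` in a functional assay on the whole organism with Canis familiaris (Canis lupus familiaris) as the target, at a dose of 8 mg/kg by the oral route; a higher number here means a stronger effect of the compound at the dose given, a lower number a weaker effect: compound 1 gives 96%.
Compound 2 `Cc1nc2c(OCc3ccccc3)cccn2c1CN`: compound 2 gives 9%.
Compound 3 `Cc1nc2c(OCc3ccccc3)cccn2c1/N=C/N(C)C`: compound 3 gives 0%.

Compound 3 stands lowest of the three numbers; nearest is compound 2, a number 9 percentage points lower from compound 2 to compound 3 (within the scatter), furthest compound 1, a number 96 percentage points lower from compound 1 to compound 3 (beyond the scatter). Compound 4 `CCCNc1c(C)nc2c(OCc3ccccc3)cccn12` differs from compound 3 in one place: a group of 4 heavy atoms (3 carbon, 1 nitrogen; no ring) in place of a group of 5 heavy atoms (3 carbon, 2 nitrogen; no ring), on an aromatic carbon. Among the measured compounds shown here, two steps bear on this. a number 96 percentage points lower from compound 1 to compound 3 (beyond the scatter) shows the large loss on going from amino to the group that now leaves, and a number 87 percentage points lower from compound 1 to compound 2 (beyond the scatter) shows that a group with one hydrogen-bond donor does not by itself restore the effect. A recovery toward compound 1 is possible but uncertain, so a rise is expected, a number 40 percentage points higher from compound 3 to compound 4 (beyond the scatter), wide in range. For compound 4 the expected value in this assay is 40%, between 5% and 85%.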

Compound 4, a percentage reported as inhibition, in the whole organism at one dose (the size of the read-out at that dose, not a potency): 68%
Compound 4: the middle estimate sits 28 percentage points below what was measured; the range from low to high includes it.
By their numbers in this assay, from the lowest: compounds 3 and 2 (each within the scatter of the next); then compound 4; then compound 1.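

Propylamino on this aromatic carbon brings back much of the effect in this assay, both against the group it replaces in compound 3 (a number 68 percentage points higher from compound 3 to compound 4 (beyond the scatter)) and against aminomethyl (a number 59 percentage points higher from compound 2 to compound 4 (beyond the scatter)). Unlike the two earlier changes, this one keeps a large part of the effect of compound 1: propyl in place of hydrogen on the nitrogen is a modest step (a number 28 percentage points lower from compound 1 to compound 4 (beyond the scatter)).

Going by these compounds, whether ethylamino, butylamino or a ring amine such as piperidine would keep the effect stays open. No measurement here accounts for the recovery.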